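Compound 3 to compound 4: a pyridin-2-yl swap

This account rests on a few compounds, and the source may have more. Where it says the series, first, only, none or still open, it means among the compounds named here.

In an ADME assay for permeability, using PAMPA, in phosphate buffer, with a stated time of 18 h, at pH 7.4 (on this read-out lower numbers stand for lower permeability and higher numbers for higher permeability), compound 1 `Nc1ccc2oc(N3CCN(c4ccccc4)CC3)nc2c1` gives 10.3 10^-6 cm/s, compound 2 `Nc1ccc2oc(N3CCN(c4ccc(F)cc4)CC3)nc2c1` gives 10.7 10^-6 cm/s and compound 3 `Cc1ccc(N2CCN(c3nc4cc(N)ccc4o3)CC2)cc1` gives 10.4 10^-6 cm/s. Compound 3 therefore stands within the scatter of both other compounds, and the three numbers form a single level. Compound 4 `Nc1ccc2oc(N3CCN(c4ccccn4)CC3)nc2c1` is the next to be read, with this difference: pyridin-2-yl in place of 4-methylphenyl on an amine nitrogen in a ring. In words, pyridin-2-yl takes the place of 4-methylphenyl on an amine nitrogen in a ring.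

For the measured compounds named here, three measured steps bear on this change: a 1.0-fold higher number from compound 1 to compound 2 (0.02 log units; within the scatter), a 1.0-fold higher number from compound 1 to compound 3 (0.00 log units; within the scatter) and a 1.0-fold lower number from compound 2 to compound 3 (0.01 log units; within the scatter). Each lies within the scatter, but each only exchanges a group on an aromatic carbon. None of them introduces a hetero atom into the aromatic ring, so the support is indirect. The expected move is a 1.1-fold lower number from compound 3 to compound 4 (0.04 log units; within the scatter), an estimated step that stays within the scatter. For compound 4 the estimate is 9.5 10^-6 cm/s, with an expected range from 5.5 10^-6 cm/s to 14 10^-6 cm/s.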

Compound 4, apparent permeability: 9.44 10^-6 cm/s
Compound 4: middle estimate off by 1.0-fold (0.00 log units), on the high side; the measured number falls inside the stated range.
By their numbers in this assay, from the lowest: compounds 4, 1, 3 and 2 (each within the scatter of the next).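

In this assay compound 4 carries a hetero atom in the aromatic ring and a hydrogen-bond acceptor at this place, yet all three new steps lie within the scatter: a 1.1-fold lower number from compound 3 to compound 4 (0.04 log units; within the scatter), a 1.1-fold lower number from compound 2 to compound 4 (0.05 log units; within the scatter) and a 1.1-fold lower number from compound 1 to compound 4 (0.04 log units; within the scatter). The level seen so far therefore extends from exchanges on an aromatic carbon to the exchange of the whole aromatic group on the amine nitrogen in a ring, and the four compounds form one level. No measurement shown accounts for this absence of a separation.

Open, on these data alone, is whether the level holds with a group of another kind on this nitrogen, such as a carboxylic acid or a longer alkyl chain. As far as these compounds go, all four compounds share one core, so the effect of any change there also remains open.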